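The compounds below may be only part of what the source reports. "The series", "measured", "known", "first", "only" and "open" are said of these compounds alone.

Compound 1 `Nc1sc(-c2ccccc2)c(-c2cccc(C(F)(F)F)c2)c1C(=O)c1ccccc1` — 2.3 uM
Compound 2 `CCOC(=O)c1c(N)sc(-c2ccccc2)c1-c1cccc(C(F)(F)F)c1` — a limit, > 10 uM
Compound 3 `CCOC(=O)c1c(N)sc(-c2ccc([N+](=O)[O-])cc2)c1-c1cccc(C(F)(F)F)c1` — a limit, > 10 uM

In a functional assay on CHO-K1 cells for agonist activity at adenosine receptor A1 (Homo sapiens), read by GTPgammaS binding (on this read-out higher numbers stand for an effect only at larger amounts of compound and lower numbers for an effect already at smaller amounts), compound 1 gives 2.3 uM. For compound 2 the assay reports only a limit, > 10 uM. For compound 3 it likewise reports only a limit, > 10 uM. Compound 1 thus stands as the only number shown; the other two sit at the limit of > 10 uM in this assay, at which 2 of the 3 values shown sit. Among the measured compounds shown here, the step of an at least 4.3-fold higher number from compound 1 to compound 2 (0.63 log units; beyond the scatter) is the one readable change, and a step that the two limits leave unreadable from compound 2 to compound 3 cannot be sized.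

Compound 4 `Nc1sc(Cl)c(-c2cccc(C(F)(F)F)c2)c1C(=O)c1ccccc1` differs from compound 1 by chloro in place of phenyl on an aromatic carbon. Neither measured step concerns this position, so no direct guide exists. Compound 4 is expected to lose some activity, a step of a 2.2-fold higher number from compound 1 to compound 4 (0.34 log units; beyond the scatter). Compound 4 is therefore estimated at 5 uM, within 1.5 uM to 15 uM.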

Compound 4, concentration for half-maximal effect: > 10 uM
Compound 4 was reported as a limit; the forecaster's own chance of this, stated with the estimate: 25%; at least 2.0-fold (0.30 log units) between middle value and limit.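

Among the compounds shown here, at this position, next to the ring sulfur, the first change in the group itself proves readable in this assay: chloro in place of phenyl brings an at least 4.3-fold higher number from compound 1 to compound 4 (0.63 log units; beyond the scatter). Compound 4 gives only a limit, so this step has a lower bound and no exact size. With compound 4, the benzoyl series also reaches the limit that the ethyl esters had shown: the limit of > 10 uM in this assay, at which 3 of the 4 values shown sit.

The compounds shown leave open whether a methyl, a cyclohexyl ring or an amine at this position would give a measurable number in this assay. Also open, on these data alone, is whether nitro on the phenyl would do so with the benzoyl group in place.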